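This account rests on a few compounds, and the source may have more. Where it says the series, first, only, none or still open, it means among the compounds named here.

Measured in a functional assay (aorta) for inhibition, with Rattus norvegicus as the target, with a stated time of 8 days; a higher number here means a weaker inhibitor, a lower number a stronger inhibitor:
compound 1 `CN(C)c1nsc(-c2ccc(N3CCN(c4cccc(C(F)(F)F)c4)CC3)nn2)n1`: 6 nM; 0.4 nM (2 entries)
compound 2 `Cc1nsc(-c2ccc(N3CCN(c4cccc(C(F)(F)F)c4)CC3)nn2)n1`: 0.3 nM
compound 3 `Cc1nsc(-c2ccc(N3CCN(c4cc(C(F)(F)F)cc(C(F)(F)F)c4)CC3)nn2)n1`: < 0.1 nM (a limit of the assay)

Compound 3 has no single number, only the limit of < 0.1 nM. Compound 4 `CN(C)c1nsc(-c2ccc(N3CCN(c4cc(C(F)(F)F)cc(C(F)(F)F)c4)CC3)nn2)n1` carries dimethylamino in place of methyl on an aromatic carbon.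

For the measured compounds named here, the one measured step, an at least 3.0-fold lower number from compound 2 to compound 3 (0.47 log units; beyond the scatter), is a different change, trifluoromethyl in place of hydrogen on an aromatic carbon. The same exchange of methyl for dimethylamino does link compound 2, at 0.3 nM, to compound 1. The entries of compound 1 disagree, however: the several entries of compound 1 in this assay, 6 nM; 0.4 nM (2 entries). One entry lies close to the value of compound 2, and the other is a clearly higher number.

A modest rise in the number is therefore expected in this assay, estimated as an at least 2.0-fold higher number from compound 3 to compound 4 (0.30 log units; that floor lies within the scatter). For compound 4 the estimated value is 0.2 nM, with an expected range from 0.04 nM to 2 nM.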

Compound 4, half-maximal inhibitory concentration: 0.1 nM
The estimate for compound 4 lay 2.0-fold (0.30 log units) above the measured number, within the range that was stated.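

In this assay compound 4 gives 0.1 nM, so dimethylamino at this carbon keeps the number that low when two trifluoromethyl groups are present. Going by these compounds, the exchange gives a number no lower from compound 3 to compound 4 (the limit leaves the size open), and as compound 3 has only a limit of the assay, the true cost of the change stays unknown. The same exchange with one trifluoromethyl group gave no clear reading: the several entries of compound 1 in this assay, 6 nM; 0.4 nM (2 entries)

On these data alone, what a primary amine or a methoxy group would do at this carbon remains open. So does whether the dimethylamino exchange raises the number at all with two trifluoromethyl groups present.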